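The source may report more compounds than this note shows. Statements on the series, on what has been measured and on what is new or still open speak of the compounds shown alone.

Working notes on the series, read in a functional assay on A-375 cells (Homo sapiens) for antiproliferative activity; a higher number here means a weaker inhibitor, a lower number a stronger inhibitor. Compound 1 `O=C(Nc1ccc(-c2c[nH]cn2)cc1)C1CCCN(Cc2ccc(F)c(F)c2)C1` is reported only as a limit of the assay, > 20000 nM. Compound 2 `O=C(Nc1ccc(-c2ccoc2)cc1)C1CCCN(Cc2ccc(F)c(F)c2)C1` gives 1290 nM. Compound 3 `O=C(Nc1ccc(-c2ccsc2)cc1)C1CCCN(Cc2ccc(F)c(F)c2)C1` gives 950 nM, and the comparison with compound 2 stays within the scatter: a 1.4-fold lower number from compound 2 to compound 3 (0.13 log units; within the scatter). Within the data shown here, compound 3 therefore stands level with compound 2, and the only other compound is known by its limit alone.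

Next is compound 4 `O=C(Nc1ccc(-c2cc[nH]c2)cc1)C1CCCN(Cc2ccc(F)c(F)c2)C1`, with 1H-pyrrol-3-yl in place of thiophen-3-yl on an aromatic carbon.

Among the measured compounds shown here, three measured steps bear on this change. The exchange of one ring for the other in a 1.4-fold lower number from compound 2 to compound 3 (0.13 log units; within the scatter) suggests that compound 3 and compound 2 tolerate a swap of the single hetero atom. Against that, the large steps of an at least 15-fold lower number from compound 1 to compound 2 (1.19 log units; beyond the scatter) and an at least 21-fold lower number from compound 1 to compound 3 (1.32 log units; beyond the scatter) start from compound 1, whose 1H-imidazol-4-yl, like the entering 1H-pyrrol-3-yl, carries a hydrogen on ring nitrogen. A moderate move to a higher number in this assay is therefore expected, smaller than those large steps, though a result within the scatter of compound 3 remains possible. The expected change is a 3.2-fold higher number from compound 3 to compound 4 (0.50 log units; beyond the scatter). Compound 4 is estimated at 3000 nM, with an expected range of 900 nM to 12000 nM.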

Compound 4, half-maximal inhibitory concentration: 1420 nM
For compound 4 the middle estimate is 2.1-fold (0.32 log units) above the measured one; the measured number falls inside the stated range.
By their numbers in this assay, from the lowest: compounds 3, 2 and 4 (each within the scatter of the next). At a limit, above all of these: compound 1.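

In this assay, the hydrogen-bond donor entering with 1H-pyrrol-3-yl leaves the reading within the scatter of both rings without one: a 1.5-fold higher number from compound 3 to compound 4 (0.17 log units; within the scatter), and a 1.1-fold higher number from compound 2 to compound 4 (0.04 log units; within the scatter). A hydrogen on ring nitrogen therefore does not by itself go with the drop seen at compound 1, and at this position, para to a large group, the three rings with one hetero atom read alike, with only 1H-imidazol-4-yl set apart: an at least 14-fold lower number from compound 1 to compound 4 (1.14 log units; beyond the scatter). That step gives a bound and not a measured size, because compound 1 stands at a limit of the assay: the limit of > 20000 nM in this assay, at which 1 of the 4 values shown sits.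

As far as these compounds go, how a 1H-pyrazol-4-yl or pyridin-3-yl ring, a plain phenyl ring, or a carboxylic acid or aminomethyl group on the same aromatic carbon would read in this assay stays open, and with it whether the separation belongs to 1H-imidazol-4-yl alone. From the compounds shown here alone, the true distance between compound 1 and the other three compounds also remains unknown.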